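The source may report more compounds than this note shows. Statements on the series, on what has been measured and on what is new or still open speak of the compounds shown alone.

Of the compounds shown here, three built on one shared core have been measured in a physicochemical assay for lipophilicity, at pH 7.4 (a lower number here means a more polar compound, a higher number a more lipophilic compound), and all three reach the same ceiling. Compound 1 `Cc1cc(C(=O)NC(C)C)nn1Cc1cc(Cl)ccc1OCc1ccccc1` gives only a limit of the assay, > 3.7. Compound 2 `Cc1cc(NC(=O)C(C)C)nn1Cc1cc(Cl)ccc1OCc1ccccc1` likewise returns a limit, > 3.7. Compound 3 `Cc1cc(NC(=O)C2CCOC2)nn1Cc1cc(Cl)ccc1OCc1ccccc1` also stops at a limit, > 3.7. Given (the limit of > 3.7 in this assay, at which 3 of the 3 values shown sit), no step among them can be sized: a step that the two limits leave unreadable from compound 1 to compound 2, a step that the two limits leave unreadable from compound 1 to compound 3 and a step that the two limits leave unreadable from compound 2 to compound 3. Compound 4 `Cc1cc(NC(=O)c2c(F)cccc2F)nn1Cc1cc(Cl)ccc1OCc1ccccc1` differs from compound 3 in one place: 2,6-difluorophenyl in place of oxolan-3-yl on a carbonyl carbon. For the measured compounds named here, the one measured step on the same carbonyl carbon, a step that the two limits leave unreadable from compound 2 to compound 3, offers no readable size, so no direction can be drawn from the data. The step is nonetheless expected to be an increase, a step that the limit leaves unreadable from compound 3 to compound 4. Compound 4 is therefore estimated at 4.6, between 3.9 and 5.3, most likely reported again only as a limit.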

Compound 4, distribution coefficient: > 3.7
Compound 4 ended at the assay's limit; the forecaster's own chance of this, stated with the estimate: 90%; the middle value is on the limit's open side.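

In this assay, for the compounds shown here, compound 4 gives > 3.7, again only a limit of the assay, so no step between compound 4 and compound 1, compound 2 or compound 3 can be read: the limit of > 3.7 in this assay, at which 4 of the 4 values shown sit. The compounds shown leave open how far apart their true values lie.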